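Trimming a Benzyl to Methyl on a Weak Antiproliferative

The source may report more compounds than this note shows. Statements on the series, on what has been measured and on what is new or still open speak of the compounds shown alone.

Compound 1 `CCCSc1nc(Cl)c2c(n1)N(Cc1ccccc1)C(C(=O)N1CCN(Cc3ccccc3)CC1)N2` is tested in a functional assay on MGC-803 cells (Homo sapiens) for antiproliferative activity, read by MTT assay, with a stated time of 72 h (a higher number here means a weaker inhibitor, a lower number a stronger inhibitor), where compound 1 gives 51200 nM. That is the only numerical result shown. Compound 2 `CCCSc1nc(Cl)c2c(n1)N(Cc1ccccc1)C(C(=O)O)N2` reaches only a limit of the assay, > 64000 nM. Going by the values given here, compound 1 therefore stands as the single measured number, the other entry sitting at the limit of > 64000 nM in this assay, at which 1 of the 2 values shown sits. Compound 3 `CCCSc1nc(Cl)c2c(n1)N(Cc1ccccc1)C(C(=O)N1CCN(C)CC1)N2` differs from compound 1 in one place: hydrogen in place of phenyl on a saturated chain carbon bound to an amine nitrogen in a ring. Among the compounds with values here, no pair of measured compounds shows this change, so its size is unknown; a small step, within the scatter or slightly toward weaker inhibition, is expected in this assay. Compound 3 is expected to give 60000 nM, between 25000 nM and 130000 nM, a step of a 1.2-fold higher number from compound 1 to compound 3 (0.07 log units; within the scatter).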

Compound 3, half-maximal inhibitory concentration: > 64000 nM
Compound 3: only a limit was reported (the forecaster's own chance of this, stated with the estimate: 45%); middle value at least 1.0-fold (0.02 log units) from the limit.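

Cutting benzyl to methyl gives an at least 1.2-fold higher number from compound 1 to compound 3 (0.09 log units; that floor lies within the scatter). Compound 3 reads only as a limit in this assay, so this change brings no visible gain in inhibition, and the step involving compound 2 cannot be read. Most of the compounds shown now sit at one ceiling: the limit of > 64000 nM in this assay, at which 2 of the 3 values shown sit.

As far as these compounds go, how much the benzyl itself contributes remains open, as the true size of the step is unknown. From the compounds shown here alone, whether a phenethyl group or a chlorobenzyl group in its place would give a clearly stronger inhibitor also remains open.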